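A Nitrophenyl Swap in a Weakly Active Series

The source may hold more compounds than are shown below. What is called first, only, known or untested is meant among the compounds shown, and "the series" means these compounds.

For the measured compounds named here, in a functional assay on A549 cells (Homo sapiens) for antiproliferative activity, read by MTT assay (a higher number here means a weaker inhibitor, a lower number a stronger inhibitor), the compounds measured so far sit at the weak end. Going by the values given here, compound 1 `CC1(C)CCc2c(ccc(C(=O)/C=C/c3ccc(OCc4cn(-c5ccc(Cl)cc5)nn4)cc3)c2O)O1` reads "not active" (no number reported) with no number, compound 2 `CC1(C)CCc2c(ccc(C(=O)/C=C/c3ccc(OCc4cn(-c5ccc(Br)cc5)nn4)cc3)c2O)O1` reads 129000 nM as the only number, and compound 3 `Cc1c(-n2cc(COc3ccc(/C=C/C(=O)c4ccc5c(c4O)CCC(C)(C)O5)cc3)nn2)cccc1[N+](=O)[O-]` reads "not active" (no number reported) with no number either, so compound 3 has no single value to start from. Compound 4 `COc1ccc(-n2cc(COc3ccc(/C=C/C(=O)c4ccc5c(c4O)CCC(C)(C)O5)cc3)nn2)c([N+](=O)[O-])c1` carries 4-methoxy-2-nitrophenyl in place of 2-methyl-3-nitrophenyl on an aromatic nitrogen and keeps the shared core. Among the compounds with values here, no measured step shows what such a swap does, so in this assay no gain beyond the scatter is expected, and compound 4 should stay weak, either without a number or near compound 2 at 129000 nM in this series. Compound 4 is expected to land at 100000 nM (estimated range 30000 nM to 300000 nM) if it gives a number at all.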

Compound 4, half-maximal inhibitory concentration: "not active" (no number reported)
Compound 4: no number reported; there is nothing to compare the estimate with.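

In this assay compound 3 and compound 4 both stand without a number, and no step can be read between them. What 4-methoxy-2-nitrophenyl does in place of 2-methyl-3-nitrophenyl stays open, and nothing shown offers an explanation.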